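The source may hold more compounds than are shown below. What is called first, only, known or untested is meant among the compounds shown, and "the series" means these compounds.

Measured so far:
Compound 1, `CC(C)(C)CCOc1cccc(O)c1C(=O)/C=C/c1ccc(C(=O)O)cc1`: 2800 nM
Compound 2, `CC(C)CCCOc1cccc(O)c1C(=O)/C=C/c1ccc(O)cc1`: 11000 nM
Compound 3, `CC(C)(C)CCOc1cccc(O)c1C(=O)/C=C/c1ccc(S(N)(=O)=O)cc1`: 1200 nM

These three compounds share one core and were all tested in an assay on THP-1 cells for inhibition of nuclear factor NF-kappa-B complex (Homo sapiens), with stated times of 2 h and 16 h; on this read-out lower numbers stand for stronger inhibition and higher numbers for weaker inhibition. Compound 2 stands at the weak end of the three: compound 1 gives a lower number, and compound 3 gives a lower number still, both gaps lying beyond the usual scatter. Among the measured compounds shown here, the only measured step between two compounds that differ in a single place, a 2.3-fold lower number from compound 1 to compound 3 (0.37 log units; beyond the scatter), concerns the group at the far end of the molecule and leaves the alkoxy chain untouched.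

Compound 4, `CC(C)COc1cccc(O)c1C(=O)/C=C/c1ccc(O)cc1`, has not yet been measured. It differs from compound 2 in one place: isopropyl in place of isopentyl on a saturated chain carbon bound to an oxygen on an aromatic ring. For the measured compounds named here, no measured pair shows what shortening this chain does, so the step from compound 1 to compound 3 does not bear on it, and the expectation rests on the bare fact that the change is small and sits away from the end that did shift the numbers. A step of no more than the usual scatter is therefore expected, in either direction. On that basis compound 4 is estimated at 13000 nM, with a range from 5000 nM to 35000 nM. The expected step is a 1.2-fold higher number from compound 2 to compound 4 (0.07 log units; within the scatter), which lies within the scatter.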

Compound 4, half-maximal inhibitory concentration: 8000 nM
Estimate against measurement, compound 4: 1.6-fold (0.21 log units) above; the measured number falls inside the stated range.
By their numbers in this assay, from the lowest: compound 3; then compound 1; then compounds 4 and 2 (each within the scatter of the next).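

In this assay, among the compounds shown here, the swap of isopropyl for isopentyl on a saturated chain carbon bound to an oxygen on an aromatic ring gives the first direct reading at this position: a 1.4-fold lower number from compound 2 to compound 4 (0.14 log units; within the scatter), so the read-out does not separate the two compounds. The chain can therefore differ by this much, with the rest of the molecule unchanged, without a change in the number that stands clear of ordinary measurement noise, whereas sulfamoyl in place of carboxy on an aromatic carbon gave a 2.3-fold lower number from compound 1 to compound 3 (0.37 log units; beyond the scatter). No separate measurement is available to explain this result, so it stands as an observation only.

On these data alone, it remains open whether a much longer chain, or a chain ending in an amine or a carboxylic acid, would move the number beyond the scatter. As far as these compounds go, it is also open whether the same chain swap would give a similar result on compounds carrying the carboxy or sulfamoyl group rather than the hydroxy group shared by compound 2 and compound 4.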